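The source may report more compounds than this note shows. Statements on the series, on what has been measured and on what is new or still open speak of the compounds shown alone.

Measured in an assay (Oryctolagus cuniculus) for inhibition of platelet-activating factor receptor (Cavia porcellus); on this read-out lower numbers stand for stronger inhibition and higher numbers for weaker inhibition:

Compound 1 `C[C@@H]1CC[C@H]2C(=O)[C@H]3O[C@]3(C)CC[C@@H]3O[C@@]3(C)CC[C@]1(C)[C@H]2C=O` gives 17000 nM
Compound 2 `CC(=O)OC[C@H]1[C@H]2CC[C@@H](C)[C@]1(C)CC/C(C)=C/CC[C@@]1(C)O[C@@H]1C2=O` gives 410 nM
Compound 3 `CC(=O)OC[C@H]1[C@H]2CC[C@@H](C)[C@]1(C)CC/C(C)=C/CC[C@@]1(C)O[C@@H]1[C@@H]2O` gives 80 nM

Among these three, compound 3 stands at the lowest number in this assay; its distance to compound 2 and, more widely, to compound 1 lies beyond the usual scatter, so compound 3 is the strongest inhibitor of the three measured compounds.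

Compound 4 `C/C1=C\CC[C@@]2(C)O[C@@H]2[C@H](O)[C@@H]2CC[C@@H](C)[C@](C)(CC1)[C@H]2COC(=O)N(C)C` has not yet been measured. It differs from compound 3 in one place: dimethylamino in place of methyl on a carbonyl carbon. Among the compounds with values here, no comparable pair of measured compounds shows what such a change does in this assay, so the direction of the step cannot be read from the data. The change is small in size and leaves donors and acceptors unchanged, and compound 3 already provides the lowest number seen.

Compound 4 is therefore expected to give about 100 nM in this assay, within a range of 30 nM to 350 nM. The estimated step of a 1.3-fold higher number from compound 3 to compound 4 (0.10 log units; within the scatter) is expected to stay near or within the usual scatter.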

Compound 4, half-maximal inhibitory concentration: 180 nM
The estimate for compound 4 lay 1.8-fold (0.26 log units) below the measured number; low and high end bracket the measured number.
By their numbers in this assay, from the lowest: compound 3; then compound 4; then compound 2; then compound 1.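

In this assay, within the data shown here, dimethylamino in place of methyl on a carbonyl carbon gives the first single-place comparison in this set, a 2.3-fold higher number from compound 3 to compound 4 (0.35 log units; beyond the scatter). This modest step lies beyond the scatter, so at this position the acetoxymethyl and ((dimethylcarbamoyl)oxy)methyl groups are not interchangeable, although compound 4 still reaches 180 nM. Nothing available accounts for the shift.

The compounds shown leave open how a methylamino or a plain amino group on the same carbonyl carbon, or a longer chain such as propionyl in place of acetyl, would read in this assay. They also leave open whether the same change from acetoxymethyl to ((dimethylcarbamoyl)oxy)methyl would produce a step of similar size on compound 2.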